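A few compounds are considered here, and "the series" means these few. Any claim that something is new, unique, unknown or untested is made for them only; others in the source may bear on it.

Notes on the series. Compound 1 `CCOc1cc(OC)c(Br)cc1C(C)=O` and compound 2 `CCCCOc1cc(OC)c(Br)cc1C(C)=O` share one core; in a functional assay, with stated times of 30 s and 6 min, in the presence of a further agent that is not named here (on this read-out lower numbers stand for stronger inhibition and higher numbers for weaker inhibition), compound 1 gives 37900000 nM and compound 2 gives 38200000 nM. The change between them, (ethyl in place of hydrogen on a saturated chain carbon, two bonds along the chain from an oxygen on an aromatic ring), gave a 1.0-fold higher number from compound 1 to compound 2 (0.00 log units; within the scatter). Compound 3 `CCCCOc1cc(OC)ccc1C(C)=O` carries hydrogen in place of bromo on an aromatic carbon relative to compound 2, and in this assay compound 3 gives 15600000 nM, which is a 2.4-fold lower number from compound 2 to compound 3 (0.39 log units; beyond the scatter). The difference between the core of compound 3 and the core of compound 1 is not broken down here.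

Compound 4 `CCCCCCOc1cc(OC)ccc1C(C)=O` is not yet measured. It differs from compound 3 by ethyl in place of hydrogen on a saturated chain carbon, four bonds along the chain from an oxygen on an aromatic ring. Going by the values given here, this is the same kind of change as the one from compound 1 to compound 2, not the same: there the entering ethyl sits two bonds along the chain from an oxygen on an aromatic ring, here four bonds along the chain. Among the compounds with values here, the single earlier instance, a 1.0-fold higher number from compound 1 to compound 2 (0.00 log units; within the scatter), was flat. On that basis the expected step for compound 4 is a 1.0-fold lower number from compound 3 to compound 4 (0.02 log units; within the scatter). The estimated value for compound 4 in this assay is 15000000 nM, expected to fall between 6000000 nM and 40000000 nM.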

Compound 4, half-maximal inhibitory concentration: 18000000 nM
Estimate against measurement, compound 4: 1.2-fold (0.08 log units) below; low and high end bracket the measured number.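

In this assay, the entering ethyl on the chain of compound 3 leaves the number flat (a 1.2-fold higher number from compound 3 to compound 4 (0.06 log units; within the scatter)), and this step does not differ from the earlier one on the core of compound 1, as the two side by side show: the same change on two cores in this assay, a 1.0-fold higher number (0.00 log units; within the scatter) from compound 1 to compound 2 and a 1.2-fold higher number (0.06 log units; within the scatter) from compound 3 to compound 4, 1.1-fold (0.06 log units) apart, within the scatter of two such steps.
Across these two cores, with and without bromo, adding ethyl to the chain therefore carried over as a flat step, so in this small set the core made no readable difference to this change.
Going by these compounds alone, this does not show that the change is independent of the core in general, since it rests on only two pairs, and the entering ethyl sits two bonds along the chain from the oxygen in one pair and four bonds along in the other, so core and place cannot be separated.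

As far as these compounds go, whether the flat response persists with a longer chain than that of compound 4, or with a chain ending in an amine or a carboxylic acid, remains open.
Also open, from the compounds shown here alone, is whether the step seen on replacing bromo with hydrogen (a 2.4-fold lower number from compound 2 to compound 3 (0.39 log units; beyond the scatter)) recurs with the chain of compound 4.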